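This account rests on a few compounds, and the source may have more. Where it says the series, first, only, none or still open, it means among the compounds named here.

In a functional assay on NB-4 cells (Homo sapiens) for cytotoxicity, read by CCK-8 assay, with a stated time of 24 h (on this read-out higher numbers stand for weaker inhibition and lower numbers for stronger inhibition), compound 2 `C=CC(=O)N1C(=O)CCSc2ccccc21` gives 22400 nM, and compound 1 `C=CC(=O)N1C(=O)CC(c2ccc(C(F)(F)F)cc2)Sc2ccccc21` gives 38600 nM. For the measured compounds named here, these two numbers lie within the usual scatter of each other, so compound 2 stands level with the only other compound measured. Compound 3 `C=CC(=O)N1C(=O)CC(c2ccccc2)Sc2ccccc21` differs from compound 2 by one change: phenyl in place of hydrogen on a saturated ring carbon. Compound 1 also bears an aromatic ring on a saturated ring carbon and gives 38600 nM, so only a small shift seems likely. The expected change is a 1.3-fold higher number from compound 2 to compound 3 (0.13 log units; within the scatter), which stays within the scatter. For compound 3 the estimate is 30000 nM, with a range of 14000 nM to 60000 nM.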

Compound 3, half-maximal inhibitory concentration: 35500 nM
The estimate for compound 3 lay 1.2-fold (0.07 log units) below the measured number, within the range that was stated.
By their numbers in this assay, from the lowest: compounds 2, 3 and 1 (each within the scatter of the next).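

Placing phenyl on the saturated ring carbon next to the ring sulfur gives a 1.6-fold higher number from compound 2 to compound 3 (0.20 log units; within the scatter) in this assay and so shows no readable change, even though an aromatic ring enters at this position. Hydrogen in place of trifluoromethyl on the aromatic ring gives a 1.1-fold lower number from compound 1 to compound 3 (0.04 log units; within the scatter) and also shows no readable change, so compound 1 and compound 3 stand level. No measurement here offers an explanation for these results. From the compounds shown here alone, whether an amine or carboxylic acid on the phenyl ring would shift the number remains open. So does whether a longer chain on this saturated ring carbon would do so.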